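Aryl piperazine swap on the aminothiazole amide series

A few compounds are considered here, and "the series" means these few. Any claim that something is new, unique, unknown or untested is made for them only; others in the source may bear on it.

Compound 1 `O=C(CN1CCN(c2cccc(F)c2)CC1)Nc1nc2c(s1)CCCC2` was tested in an assay on isolated protein for inhibition of long-chain fatty acid transport protein 1 (Homo sapiens), read by scintillation counting, with a stated time of 20 min; on this read-out higher numbers stand for weaker inhibition and lower numbers for stronger inhibition. For compound 1 the result is only a limit of the assay, > 1000 nM. Compound 2 `CC1CCc2sc(NC(=O)CN3CCN(c4ccc(F)cc4)CC3)nc2C1` gives 26 nM in this assay. Compound 3 `O=C(CN1CCN(c2ccccn2)CC1)Nc1nc2c(s1)CCCC2` is not yet measured; it differs from compound 1 by pyridin-2-yl in place of 3-fluorophenyl on an amine nitrogen in a ring. Compound 1 stands at the limit of > 1000 nM in this assay, at which 1 of the 2 values shown sits, so only a large gain would register as a number. The step from compound 1 to compound 3 is expected to be small, a step that the limit leaves unreadable from compound 1 to compound 3, not beyond the scatter in either direction. Compound 3 is estimated at 1500 nM, within a range from 300 nM to 8000 nM.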

Compound 3, half-maximal inhibitory concentration: 200 nM
Estimate against measurement, compound 3: 7.5-fold (0.88 log units) above; measured number below the stated range.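

In this assay, pyridin-2-yl in place of 3-fluorophenyl on an amine nitrogen in a ring gives an at least 5.0-fold lower number from compound 1 to compound 3 (0.69 log units; beyond the scatter). The group on this nitrogen therefore matters on the core of compound 1, which compound 1 and compound 2 could not show, as they differ in more than one place. The true size of the step stays unknown because compound 1 stands at a limit of the assay: the limit of > 1000 nM in this assay, at which 1 of the 3 values shown sits.

On these data alone, whether the gain follows from the ring nitrogen of pyridin-2-yl or from the removal of the fluorine stays open. A plain phenyl or a pyrimidin-2-yl on the same nitrogen would separate the two.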